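Three Sulfonamides at the Assay Limit, One Methoxy Analogue

This account rests on a few compounds, and the source may have more. Where it says the series, first, only, none or still open, it means among the compounds named here.

Compound 1 `Cc1ccccc1S(=O)(=O)Nc1ccc(-c2nc3ccccc3o2)cc1` gives > 63000 nM in an assay on isolated protein for inhibition of malate dehydrogenase, mitochondrial (Sus scrofa), with stated times of 45 min and 30 min (on this read-out lower numbers stand for stronger inhibition and higher numbers for weaker inhibition), which is a limit rather than a number.
Compound 2 `Cc1cccc(S(=O)(=O)Nc2ccc(-c3nc4ccccc4o3)cc2)c1` gives > 63000 nM in this assay, again only a limit.
Compound 3 `O=S(=O)(Nc1ccc(-c2nc3ccccc3o2)cc1)c1ccccc1Cl` gives > 63000 nM in this assay, likewise a limit.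

Compound 3 therefore stands at a limit, and the two further values shown are limits as well; all three sit at the limit of > 63000 nM in this assay, at which 3 of the 3 values shown sit. The measured steps are a step that the two limits leave unreadable from compound 1 to compound 2, a step that the two limits leave unreadable from compound 1 to compound 3 and a step that the two limits leave unreadable from compound 2 to compound 3, so none of them has a readable size.

Compound 4 `COc1cccc(S(=O)(=O)Nc2ccc(-c3nc4ccccc4o3)cc2)c1` differs from compound 3 in this way: 3-methoxyphenyl in place of 2-chlorophenyl on a sulfonyl sulfur. The change at the sulfonyl sulfur resembles the earlier exchanges among compounds 1, 2 and 3, each of which left the read-out at the limit. Since every related compound stayed at the limit, no step beyond the scatter is expected, and compound 4 is estimated to give 90000 nM, between 30000 nM and 300000 nM. The expected step is a step that the limit leaves unreadable from compound 3 to compound 4.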

Compound 4, half-maximal inhibitory concentration: > 63000 nM
Compound 4 gave a limit, no number; the forecaster's own chance of this, stated with the estimate: 85%; the middle value does not contradict the limit.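

In this assay compound 4 also gives only a limit, so its steps from compound 1, compound 2 and compound 3 cannot be read, and all four compounds stand together: the limit of > 63000 nM in this assay, at which 4 of the 4 values shown sit.
Whether any change on the sulfonyl sulfur gives a measurable number in this assay remains open for the compounds shown.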